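Benzylamide variation in a naphthyridine carboxamide series

The source may hold more compounds than are shown below. What is called first, only, known or untested is meant among the compounds shown, and "the series" means these compounds.

Measured so far:
compound 1, `N[C@H]1CC[C@H](Nc2c(C(=O)NCc3ccc(F)cc3)nc(Br)c3cccnc23)CC1`: 2000 nM
compound 2, `CN(C)c1ccc(CNC(=O)c2nc(Br)c3cccnc3c2N[C@H]2CC[C@H](N)CC2)cc1`: "not determined" (no result reported) in a functional assay on SK-BR-3 cells (Homo sapiens) for cytotoxicity, read by MTT assay, with a stated time of 72 h; on this read-out lower numbers stand for stronger inhibition and higher numbers for weaker inhibition

Compound 1 carries a fluoro on the benzyl ring and in this assay gives 2000 nM. Within the data shown here, compound 2 carries a dimethylamino at the same position; for compound 2 this assay reports "not determined" (no result reported), so it has no standing on the scale and no step from it can be sized. Compound 3, `N[C@H]1CC[C@H](Nc2c(C(=O)NCc3ccc(Cl)cc3)nc(Br)c3cccnc23)CC1`, differs from compound 2 as follows: chloro in place of dimethylamino on an aromatic carbon. Because compound 2 has no value, the step from compound 2 to compound 3 in this assay cannot be given a size or a direction; it is left open. The expectation for compound 3 therefore rests on compound 1 alone, whose halogenated benzyl gives 2000 nM, and compound 3 is expected to land close to that, at an estimated 2000 nM with a range of 700 nM to 6000 nM.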

Compound 3, half-maximal inhibitory concentration: 2000 nM
Beside the measured number, compound 3's estimate shows no gap at the digits printed, within the range that was stated.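

In this assay chloro in place of fluoro on an aromatic carbon gives no change at the digits printed from compound 1 to compound 3 (within the scatter). Across these two compounds, the position para to a large group on the benzyl ring therefore accepts either halogen without a change that this read-out can separate. The step between compound 2 and compound 3 cannot be read, so dimethylamino offers no comparison here, and no measurement at hand bears on why the two halogens read alike.

On these data alone, it remains open whether a non-halogen group at this place, such as methoxy, a carboxylic acid or a primary amine, would move the value away from that of the two halogen compounds. As far as these compounds go, it also remains open whether bromo or iodo would keep the value where chloro and fluoro leave it.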